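Sulfamoylamino for Ethynyl on an Inactive Urea Scaffold

The compounds below may be only part of what the source reports. "The series", "measured", "known", "first", "only" and "open" are said of these compounds alone.

Compound 2 `C#Cc1ccc(NC(=O)Nc2cccc(-c3nc(-c4ccc(NC(=O)c5cccnc5)cc4Cl)no3)c2)cc1` was tested in a functional assay on MDA-MB-231 cells (Homo sapiens) for antiproliferative activity, read by MTT assay, with a stated time of 72 h; on this read-out higher numbers stand for weaker inhibition and lower numbers for stronger inhibition. In this assay compound 2 gives > 10000 nM, which is a limit of the assay and not a number. Compound 1 `O=C(Nc1ccccc1)Nc1cccc(-c2nc(-c3ccc(NC(=O)c4cccnc4)cc3Cl)no2)c1` in this assay likewise gives > 10000 nM, again a limit. The step that the two limits leave unreadable from compound 1 to compound 2 cannot be read, and the limit of > 10000 nM in this assay, at which 2 of the 2 values shown sit, is all that the two values show. Compound 3 `NS(=O)(=O)Nc1ccc(NC(=O)Nc2cccc(-c3nc(-c4ccc(NC(=O)c5cccnc5)cc4Cl)no3)c2)cc1` differs from compound 2 by sulfamoylamino in place of ethynyl on an aromatic carbon. Going by the values given here, no measured step bears readably on this change, so no direction can be drawn for compound 3. Compound 3 is expected in this assay at about 15000 nM (range 4000 nM to 60000 nM). The estimated step from compound 2 to compound 3 is a step that the limit leaves unreadable from compound 2 to compound 3.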

Compound 3, half-maximal inhibitory concentration: 8900 nM
Compound 3: middle estimate off by 1.7-fold (0.23 log units), on the high side, and the stated range covers the measured number.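

With sulfamoylamino on this aromatic carbon, para to a large group, this assay yields its first value that is a number and not a limit, with compound 3 at 8900 nM. The change reads as an at least 1.1-fold lower number from compound 2 to compound 3 (0.05 log units; that floor lies within the scatter), and against hydrogen as an at least 1.1-fold lower number from compound 1 to compound 3 (0.05 log units; that floor lies within the scatter), so neither step is shown to exceed the scatter. The other two values remain limits of the assay: the limit of > 10000 nM in this assay, at which 2 of the 3 values shown sit.

As far as these compounds go, the true size of both steps stays open. So does whether a simple amine or a carboxylic acid at this position would give a number at all.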